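The source may report more compounds than this note shows. Statements on the series, on what has been measured and on what is new or still open speak of the compounds shown alone.

Compound 1, `COc1cc(CNCc2ccncc2)ccc1OCc1cccc(F)c1`, gives 4800 nM in a functional assay on HeLa cells (Homo sapiens) for inhibition, with a stated time of 72 h; a lower number here means that less compound is needed, a higher number that more compound is needed for the effect.
Compound 2, `COc1cc(CNCc2cccnc2)ccc1OCc1ccc(Cl)nc1`, gives 5000 nM in this assay.
Compound 3, `Clc1ccc(COc2ccc(CNCc3ccncc3)cc2)cc1`, gives 4000 nM in this assay.

These three compounds share a core in which a benzyl-type amine is joined to a pyridine-bearing arm on one side and to an aromatic ether on the other. Among the three numbers, compound 1 stands second highest. Its nearest neighbour is compound 2, and the gap between them lies within the usual scatter of repeated measurements; the gap to compound 3, the furthest of the three, also lies within that scatter. No ordering among them can therefore be read from these values: the three compounds behave alike in this assay.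

The next compound, compound 4, `COc1cc(CNCc2ccncc2)ccc1OCc1ccc([N+](=O)[O-])cc1`, is derived from compound 1 by a single change: 4-nitrophenyl in place of 3-fluorophenyl on a saturated chain carbon bound to an oxygen on an aromatic ring. Going by the values given here, no pair of measured compounds differs in just one place, so there is no measured step to lean on. What the three measured compounds do show is that changes at both side groups leave the numbers close together. On that basis compound 4 is expected to fall close to compound 1, with a step of a 1.1-fold lower number from compound 1 to compound 4 (0.03 log units; within the scatter) that is not expected to exceed the scatter. The estimated value for compound 4 is 4500 nM, within a range from 1500 nM to 14000 nM.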

Compound 4, half-maximal effective concentration: 440 nM
Compound 4: middle estimate off by 10-fold (1.01 log units), on the high side, and the stated range ends above it.
By their numbers in this assay, from the lowest: compound 4; then compounds 3, 1 and 2 (each within the scatter of the next).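

In this assay, putting 4-nitrophenyl in place of 3-fluorophenyl on a saturated chain carbon bound to an oxygen on an aromatic ring gives an 11-fold lower number from compound 1 to compound 4 (1.04 log units; beyond the scatter), a large step well beyond the scatter. This is the first change in a single place among the compounds shown, and it reveals what the earlier numbers could not: this position is not indifferent, and the aromatic group held there can markedly alter how much compound is needed for the effect. Nothing available explains why this change has so large an effect.

The two names differ in both the group carried on the phenyl ring and the number giving its place, so the compounds shown leave open whether the nitro group, its place on the ring or the two together account for the step. Also open, from the compounds shown here alone, is whether a nitrile, a carboxylic acid or an amine on that ring would give a similar number, and whether the same swap would produce a similar step on the other compounds.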